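Carbonyl to Sulfonyl on the Ring Amine Nitrogen

A few compounds are considered here, and "the series" means these few. Any claim that something is new, unique, unknown or untested is made for them only; others in the source may bear on it.

Measured compounds:
compound 1 `Cn1cncc1CN1CC(N(CC2CCN(C(=O)c3ccco3)CC2)S(=O)(=O)c2ccccn2)Cc2cc(C#N)ccc21`: 0.5 10^-6 cm/s
compound 2 `CCS(=O)(=O)N1CCC(CN(C2Cc3cc(C#N)ccc3N(Cc3cncn3C)C2)S(=O)(=O)c2ccccn2)CC1`: 0.1 10^-6 cm/s
compound 3 `CC(C)C(=O)N1CCC(CN(C2Cc3cc(C#N)ccc3N(Cc3cncn3C)C2)S(=O)(=O)c2ccccn2)CC1`: 0.5 10^-6 cm/s

In an ADME assay on Caco-2 cells (Homo sapiens) for permeability, in the apical to basolateral direction (on this read-out higher numbers stand for higher permeability and lower numbers for lower permeability), compound 3 stands level with compound 1, the two together giving the highest numbers of the three, while compound 2 sits apart: a 5.0-fold higher number from compound 2 to compound 3 (0.70 log units; beyond the scatter). Compound 4 `CC(C)S(=O)(=O)N1CCC(CN(C2Cc3cc(C#N)ccc3N(Cc3cncn3C)C2)S(=O)(=O)c2ccccn2)CC1` differs from compound 3 by isopropylsulfonyl in place of isopropylcarbonyl on an amine nitrogen in a ring. Among the compounds with values here, two measured steps bear on this change. Going from a carbonyl to a sulfonyl group on that nitrogen gave a 5.0-fold lower number from compound 1 to compound 2 (0.70 log units; beyond the scatter), and the reverse swap gave a 5.0-fold higher number from compound 2 to compound 3 (0.70 log units; beyond the scatter). A modest drop in this assay is therefore expected for compound 4, namely a 3.3-fold lower number from compound 3 to compound 4 (0.52 log units; beyond the scatter). Compound 4 is estimated at 0.15 10^-6 cm/s, with a range from 0.05 10^-6 cm/s to 0.5 10^-6 cm/s.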

Compound 4, apparent permeability: 0.1 10^-6 cm/s
Compound 4: the middle estimate sits 1.5-fold (0.18 log units) above what was measured; the measured number falls inside the stated range.
By their numbers in this assay, from the lowest: compounds 2 and 4 (each within the scatter of the next); then compounds 1 and 3 (each within the scatter of the next).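

With the isopropyl group held constant, the swap of carbonyl for sulfonyl gives a 5.0-fold lower number from compound 3 to compound 4 (0.70 log units; beyond the scatter) in this assay, so the step now appears in a pair that differs only in that link. Ethylsulfonyl and isopropylsulfonyl do not separate, with no change at the digits printed from compound 2 to compound 4 (within the scatter) on this read-out. The furan-2-yl amide gives the same picture, with a 5.0-fold lower number from compound 1 to compound 4 (0.70 log units; beyond the scatter), so both sulfonyl compounds sit under both amides.

Nothing shown explains this gap. From the compounds shown here alone, a plain alkyl group or a urea on that ring nitrogen could fall with either pair, and that remains open.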